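From compound 1 to compound 3: adding a chloro

The source may report more compounds than this note shows. Statements on the series, on what has been measured and on what is new or still open speak of the compounds shown alone.

Values so far in a physicochemical assay for solubility, read by HPLC, in phosphate buffer, at pH 6.5 (a higher number here means a more soluble compound, a lower number a less soluble compound), are:
- compound 1 (`COC(=O)C1=C(C)NC(c2nccs2)=NC1(C)c1ccc(F)cc1`) gives 22 ug/mL
- compound 2 (`COC(=O)C1=C(C)NC(c2nccs2)=N[C@]1(C)c1ccc(F)cc1`) gives 178 ug/mL

Compound 1 has the lower of these two numbers. Within the data shown here, the one measured step (an 8.1-fold higher number from compound 1 to compound 2 (0.91 log units; beyond the scatter)) goes with the fact that one of compounds 1 and 2 is drawn with a defined configuration and the other without, at the place where they differ and adds no atom. Compound 3 (`COC(=O)C1=C(C)NC(c2nccs2)=NC1(C)c1ccc(F)cc1Cl`) is compound 1 with chloro in place of hydrogen on an aromatic carbon so 4-fluorophenyl becomes 2-chloro-4-fluorophenyl. Among the measured compounds shown here, no measured step makes that kind of swap, so the step seen sets no size for it, and no step beyond the scatter is expected in this assay here. The expected step is small (a 1.5-fold lower number from compound 1 to compound 3 (0.17 log units; within the scatter)). Compound 3 is estimated at 15 ug/mL with 5 ug/mL to 45 ug/mL as its expected range.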

Compound 3, solubility: 18 ug/mL
Compound 3: the middle estimate sits 1.2-fold (0.08 log units) below what was measured, within the range that was stated.
By their numbers in this assay, from the lowest: compounds 3 and 1 (each within the scatter of the next); then compound 2.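

In this assay, chloro in place of hydrogen, ortho to a large group, gives a 1.2-fold lower number from compound 1 to compound 3 (0.09 log units; within the scatter), so compounds 1 and 3 cannot be told apart. Among these compounds, compounds 1 and 2 differ only in drawn configuration, so this is the first measured step that adds an atom, and it stays within the scatter. No available evidence bears on this result.

From the compounds shown here alone, whether an amine or a carboxylic acid at this position would behave the same remains open. So does whether chloro would leave the number of compound 2 within the scatter.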